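The source may report more compounds than this note shows. Statements on the series, on what has been measured and on what is new or still open speak of the compounds shown alone.

Working notes on the sulfonamide series.

Of the compounds shown here, two have numbers so far. Compound 1 `Cc1noc(NS(=O)(=O)c2ccc(NCc3ccccc3)cc2)c1C` is the weaker of the two in an assay on VSM-A10 cells for antagonist activity at Endothelin-1 receptor (Rattus norvegicus) (a higher number here means a weaker inhibitor, a lower number a stronger inhibitor), where compound 1 gives 9800 nM. Compound 2 `Cc1noc(NS(=O)(=O)c2cccc3c(CN(C)C)cccc23)c1C`, which carries a different substituted aryl sulfonyl part, gives 2800 nM in this assay; the gap between the two lies beyond the usual scatter, so compound 1 stands as the higher number of the pair.

The next compound to be measured is compound 3 `Cc1noc(NS(=O)(=O)c2ccc(NC(=O)CN)cc2)c1C`. It differs from compound 1 in one place: (aminomethyl)carbonyl in place of benzyl on a nitrogen on an aromatic ring. The nitrogen on the aromatic ring keeps its attachment to aromatic carbon; only the group on that nitrogen changes.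

Among the measured compounds shown here, no pair of measured compounds shows this or any other single change, so there is no measured step to lean on. Compound 1 is already a weak inhibitor, and a substantial gain is not expected from this exchange. The estimate for compound 3 in this assay is 15000 nM, with a range from 4000 nM to 60000 nM. This corresponds to an expected step of a 1.5-fold higher number from compound 1 to compound 3 (0.18 log units; within the scatter), a small move toward a weaker inhibitor, close to the scatter.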

Compound 3, half-maximal inhibitory concentration: 6500 nM
Compound 3: the middle estimate sits 2.3-fold (0.36 log units) above what was measured; low and high end bracket the measured number.
By their numbers in this assay, from the lowest: compound 2; then compounds 3 and 1 (each within the scatter of the next).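

In this assay, the exchange at this nitrogen on an aromatic ring gives a 1.5-fold lower number from compound 1 to compound 3 (0.18 log units; within the scatter), so the two groups cannot be told apart by this read-out. The six-membered aromatic ring of the benzyl group is therefore not needed to hold the number at this level, and a smaller group with no ring, a double bond outside aromatic rings, a hydrogen-bond donor and two hydrogen-bond acceptors serves equally well in this one pair. No measurement at hand accounts for this result.

Still open, as far as these compounds go, is which part of the (aminomethyl)carbonyl group, if any, matters: an acetyl group, which keeps the carbonyl without the amine, and the unsubstituted amine on the aromatic ring would separate the two parts, while a longer aminoalkyl chain or a carboxylic acid in place of the amine would test the other end of the group. From the compounds shown here alone, it is also open whether any group on this nitrogen moves the number beyond the scatter, as one pair within the scatter defines no trend for this position.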